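Working notes: from compound 2 to compound 3

This account rests on a few compounds, and the source may have more. Where it says the series, first, only, none or still open, it means among the compounds named here.

Measured so far in a functional assay on PANC-1 cells (Homo sapiens) for cytotoxicity, read by WST assay, with a stated time of 24 h (on this read-out higher numbers stand for weaker inhibition and lower numbers for stronger inhibition), each value a limit of the assay
Compound 1 `N#Cc1ccc(CCCCCCCCC(=O)N2CCCCC2)cc1` gives > 100000 nM as a limit
Compound 2 `O=C(CCCCCCCCc1ccc(O)cc1)N1CCCCC1` gives > 100000 nM as a limit

Compound 2 stands only at a limit in this assay (> 100000 nM). Among the compounds with values here, no number is available for it, and the one other compound measured is also held at a limit.

Compound 3 `O=C(CCCCCCCCc1ccccc1F)N1CCCCC1` carries 2-fluorophenyl in place of 4-hydroxyphenyl on a saturated chain carbon, eight bonds along the chain from a carbonyl carbon.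

Within the data shown here, only one measured step bears on this change (a step that the two limits leave unreadable from compound 1 to compound 2). It also alters the aromatic end of the chain, but its size cannot be read, and both compounds rest at the same limit (the limit of > 100000 nM in this assay, at which 2 of the 2 values shown sit). The data therefore give no direction for the new change, and no step beyond the usual scatter is expected. The working expectation is an estimated a number no higher from compound 2 to compound 3 (the limit leaves the size open) for this change. Compound 3 is expected at 100000 nM with an estimated range from 25000 nM to 200000 nM in this assay, and a report as a limit alone is the likeliest outcome.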

Compound 3, half-maximal inhibitory concentration: 98900 nM
Estimate against measurement, compound 3: 1.0-fold (0.00 log units) above; low and high end bracket the measured number.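

In this assay compound 3 gives 98900 nM, the only value in the series shown that is a number and not a limit. On the saturated chain carbon, eight bonds along the chain from a carbonyl carbon, 2-fluorophenyl therefore gives a readable result, which neither 4-hydroxyphenyl nor 4-cyanophenyl gives there, and this position now has one numerical reference point. The two steps are a number no higher from compound 2 to compound 3 (the limit leaves the size open) and a number no higher from compound 1 to compound 3 (the limit leaves the size open) and give no measure of any gain, because the other two compounds both rest at the limit: the limit of > 100000 nM in this assay, at which 2 of the 3 values shown sit.

As far as these compounds go, a single number gives no trend, so it remains open whether the fluorine itself or simply the loss of the 4-substituent separates compound 3 from the other two compounds. Also open, from the compounds shown here alone, is how the result would respond to an unsubstituted phenyl, an amine or a carboxylic acid on the aromatic ring, or a longer chain between that ring and the carbonyl.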